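The source may hold more compounds than are shown below. What is called first, only, known or untested is meant among the compounds shown, and "the series" means these compounds.

Three compounds built on the shared core of compound 1, `N#Cc1cccnc1N1CCN(Cc2nc3ccccc3[nH]2)CC1`, have been read in an assay on HEK293 cells with D(4) dopamine receptor (Homo sapiens) as the target, read by FLIPR; a higher number here means a larger maximal response, a lower number a smaller maximal response. Compound 1 gives 50%. Compound 2, `O=[N+]([O-])c1ccccc1N1CCN(Cc2nc3ccccc3[nH]2)CC1`, gives 40%, and compound 3, `CS(=O)(=O)c1cccnc1N1CCN(Cc2nc3ccccc3[nH]2)CC1`, gives 27%. Among these three numbers compound 1 stands highest; compound 2 is its nearest neighbour, and that gap lies within the scatter, so no order between the two can be claimed. Among the compounds with values here, compound 3 is furthest away, and the one step between measured compounds, a number 23 percentage points lower from compound 1 to compound 3 (beyond the scatter), shows that exchanging the cyano on the aromatic carbon of compound 1 costs a modest but real amount of maximal response.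

Compound 4, `Cc1cccc(N2CCN(Cc3nc4ccccc4[nH]3)CC2)n1`, differs from compound 1 in a single place: 6-methylpyridin-2-yl in place of 3-cyanopyridin-2-yl on an amine nitrogen in a ring. Here the group that carries the cyano leaves altogether and a group with a methyl enters. Within the data shown here, only the step from compound 1 to compound 3 bears on this, and it touches the same cyano, so its size, a modest loss, is the best guide. Among the measured compounds shown here, the change in compound 4 is larger than that step, however, since the whole aryl is swapped, and no measured pair shows a methyl entering. Compound 4 is therefore expected to sit somewhat below compound 1, with a number 15 percentage points lower from compound 1 to compound 4 (beyond the scatter) as the estimated step, though the uncertainty is wide. The expected value for compound 4 in this assay is 35%, within a range from 15% to 55%.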

Compound 4, largest response reached (reported as efficacy), in percent of the reference or control that the assay uses: 36%
The estimate for compound 4 lay 1 percentage points below the measured number; the measured number falls inside the stated range.
By their numbers in this assay, from the lowest: compounds 3, 4, 2 and 1 (each within the scatter of the next, the first and the last beyond it).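

Exchanging 3-cyanopyridin-2-yl for 6-methylpyridin-2-yl on the amine nitrogen in the ring gives a number 14 percentage points lower from compound 1 to compound 4 (beyond the scatter) in this assay. This shows that the nitrile is not needed for a maximal response at this position: with a methyl-bearing ring in its place, compound 4 still reaches 36%. Together with a number 23 percentage points lower from compound 1 to compound 3 (beyond the scatter), it also gives a second case in which a change that removes the nitrile of compound 1 lowers the number beyond the scatter, although nothing available explains the drop in compound 4.

The compounds shown leave open how much of this step belongs to the nitrile leaving and how much to the methyl entering, as the two changes are joined in a single step. Equally open, going by these compounds, is how a pyridin-2-yl with no substituent, or one carrying a methoxy group or a chlorine atom, would read in this assay.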